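The source may hold more compounds than are shown below. What is called first, only, known or untested is meant among the compounds shown, and "the series" means these compounds.

In an ADME assay on PBMC cells (Homo sapiens) for cytotoxicity, with a stated time of 5 days (on this read-out higher numbers stand for weaker inhibition and lower numbers for stronger inhibition), compound 1 `O=C(/C=C/c1ccc(N2CCCCC2)cc1)c1ccsc1` gives > 100000 nM, a limit of the assay rather than a number. Compound 2 `Cc1ccc(C(=O)/C=C/c2ccc(N3CCCCC3)cc2)s1` gives 77800 nM. Compound 3 `O=C(/C=C/c1ccc(N2CCCCC2)cc1)c1ccc(Cl)s1` gives > 100000 nM, again a limit of the assay.

Compound 3 therefore stands at the limit of > 100000 nM in this assay, at which 2 of the 3 values shown sit, so its place among the three is known only as a limit. The next compound, compound 4 `O=C(/C=C/c1ccc(N2CCCCC2)cc1)c1cc(Cl)sc1Cl`, arises from compound 3 through the change (2,5-dichlorothiophen-3-yl in place of 5-chlorothiophen-2-yl on a carbonyl carbon). The measured steps that touch the ring on the carbonyl carbon are all small or unreadable: an at least 1.2-fold lower number from compound 1 to compound 2 (0.10 log units; that floor lies within the scatter), an at least 1.2-fold higher number from compound 2 to compound 3 (0.10 log units; that floor lies within the scatter) and a step that the two limits leave unreadable from compound 1 to compound 3. None of them shows a change beyond the scatter, and two of the three values shown are limits. For compound 4 the step is therefore expected to be no more than scatter, a number no higher from compound 3 to compound 4 (the limit leaves the size open), and the assay is expected to report a limit again. The estimate for compound 4 is 100000 nM, with a range from 50000 nM to 200000 nM.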

Compound 4, half-maximal inhibitory concentration: 42800 nM
For compound 4 the middle estimate is 2.3-fold (0.37 log units) above the measured one; measured number below the stated range.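

Among these compounds, on the carbonyl carbon, 2,5-dichlorothiophen-3-yl gives the first step at this position that lies beyond the scatter in this assay: an at least 2.3-fold lower number from compound 3 to compound 4 (0.36 log units; beyond the scatter), and likewise an at least 2.3-fold lower number from compound 1 to compound 4 (0.36 log units; beyond the scatter). Set against the 5-methylthiophen-2-yl of compound 2, the same group gives a 1.8-fold lower number from compound 2 to compound 4 (0.26 log units; within the scatter), so the change shows only against two of the three earlier rings. Going by these compounds, the full size of the two larger steps stays unknown, as compound 1 and compound 3 each give only a limit: the limit of > 100000 nM in this assay, at which 2 of the 4 values shown sit.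

These compounds cannot separate the effect of the added chlorine from that of moving the ring's point of attachment, as the two changes arrive together in compound 4. On these data alone, how an amine or a carboxylic acid on this ring would read in this assay also stays open.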